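This account rests on a few compounds, and the source may have more. Where it says the series, first, only, none or still open, it means among the compounds named here.

Measured in a functional assay on THP-1 cells (Homo sapiens) for inhibition, read by ELISA, with stated times of 1 h and 18 h; a lower number here means a stronger inhibitor, a higher number a weaker inhibitor:
- Compound 1 `NC(=O)[C@@H]1[C@H](Nc2nc(Nc3ccc(C(=O)N4CCCC4)cc3)ncc2-c2cccnc2)[C@H]2C=C[C@@H]1C2`: 230 nM
- Compound 2 `NC(=O)[C@@H]1[C@H](Nc2nc(Nc3cccc(C(=O)N4CCCC4)c3)ncc2-c2cccnc2)[C@H]2C=C[C@@H]1C2`: 320 nM

Compound 2, at 320 nM, lies within the usual scatter of compound 1, at 230 nM, so this assay cannot tell these two compounds apart.

Compound 3 `Cc1cnc(Nc2cccc(C(=O)N3CCCC3)c2)nc1N[C@H]1[C@@H](C(N)=O)[C@@H]2C=C[C@H]1C2` is still unmeasured. It keeps the rest of compound 2 and carries one change: methyl in place of pyridin-3-yl on an aromatic carbon. In words, this is methyl in place of pyridin-3-yl on an aromatic carbon.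

Among the compounds with values here, no measured step speaks to this change, as both measured compounds carry the pyridin-3-yl. The expectation therefore rests only on the size of the swap, in which a whole ring gives way to a single carbon. A moderate move toward a weaker inhibitor seems the more likely outcome, though this is a cautious guess and the opposite direction cannot be ruled out.

The expected change is a 1.9-fold higher number from compound 2 to compound 3 (0.27 log units; within the scatter), and this size is only an estimate. In this assay, compound 3 is estimated at 600 nM, with an expected range of 130 nM to 2800 nM.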

Compound 3, half-maximal inhibitory concentration: 100 nM
For compound 3 the middle estimate is 6.0-fold (0.78 log units) above the measured one; measured number below the stated range.
By their numbers in this assay, from the lowest: compound 3; then compounds 1 and 2 (each within the scatter of the next).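

Both earlier compounds carry the pyridin-3-yl, so they left this position untested. Replacing that whole ring with a single methyl, on the aromatic carbon ortho to a large group, gives a stronger inhibitor in this assay (a 3.2-fold lower number from compound 2 to compound 3 (0.51 log units; beyond the scatter)), which shows that, at least in this pair, the pyridin-3-yl is not needed for activity and that a much smaller group is tolerated here. Nothing in the data explains why the smaller group gives the lower number.

Within the data shown here, with only two groups seen at this position, it remains open whether the gain is specific to methyl or would also appear with a bare hydrogen, a chlorine atom, a methoxy group or a longer chain such as ethyl. From the compounds shown here alone, the finding also rests on one pair of compounds, so it is unknown whether the same swap would give a similar step on compound 1, whose other side differs from that of compound 2.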